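Cytotoxicity in the urea series: a dimethylamino analogue

A few compounds are considered here, and "the series" means these few. Any claim that something is new, unique, unknown or untested is made for them only; others in the source may bear on it.

Measured compounds and values:
compound 1 `Cc1cc(NC(=O)Nc2ccc(C(=O)O)cc2)c2ccccc2n1`: > 25000 nM
compound 2 `COC(=O)c1cccc(NC(=O)Nc2cc(C)nc3ccccc23)c1`: 26000 nM
compound 3 `Cc1cc(NC(=O)Nc2ccc(C(N)=O)cc2)c2ccccc2n1`: > 25000 nM

In an ADME assay on HEK293 cells (Homo sapiens) for cytotoxicity, with a stated time of 72 h (a higher number here means that more compound is needed for the effect, a lower number that less compound is needed), compound 1 gives > 25000 nM, which is a limit of the assay and not a number. In this assay compound 3 gives > 25000 nM, also a limit and not a number. Among the measured compounds shown here, compound 2 is therefore the only compound of the three with a number in this assay, at 26000 nM. For the measured compounds named here, the one step between measured compounds, a step that the two limits leave unreadable from compound 1 to compound 3, cannot be read in size because both ends sit at a limit; it concerns amino in place of hydroxy on a carbonyl carbon. The unmeasured compound 4 `Cc1cc(NC(=O)Nc2cccc(N(C)C)c2)c2ccccc2n1` differs from compound 2 by dimethylamino in place of methoxycarbonyl on an aromatic carbon. Going by the values given here, no measured step touches this change, and the one measured step is itself unreadable, so nothing supports a shift beyond the scatter: the evidence is only (the limit of > 25000 nM in this assay, at which 2 of the 3 values shown sit), where two of three values sit. Compound 4 is thus expected to fall in the same region, with an estimated step of no change at the digits printed from compound 2 to compound 4 (within the scatter). Compound 4 is estimated at 26000 nM, within 10000 nM to 60000 nM.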

Compound 4, half-maximal effective concentration: > 25000 nM
Compound 4 ended at the assay's limit; the forecaster's own chance of this, stated with the estimate: 50%; the middle value does not contradict the limit.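

In this assay compound 4 gives > 25000 nM, a limit and not a number. The step to it from compound 2 therefore cannot be read. The compounds shown leave open how compound 4 and compound 2 compare, and whether any single change on the shared core moves the value beyond the scatter.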